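Oxime substituent swap on the shared core

The source may hold more compounds than are shown below. What is called first, only, known or untested is meant among the compounds shown, and "the series" means these compounds.

Compound 2 `CN(C)/C(=N\O)c1ccc(Sc2cc(F)cc(C3CCOCC3)c2)cc1` sits at the highest of the two numbers given in a functional assay (blood) for inhibition, with Homo sapiens as the target; on this read-out higher numbers stand for weaker inhibition and lower numbers for stronger inhibition: compound 2 gives 280 nM, and compound 1 `C/C(=N\OCCF)c1ccc(Sc2cc(F)cc(C3CCOCC3)c2)cc1` gives 40 nM. Compound 3 `C/C(=N\O)c1ccccc1Sc1cc(F)cc(C2CCOCC2)c1` is not a number; in this assay compound 3 gives only the limit > 10000 nM (the limit of > 10000 nM in this assay, at which 1 of the 3 values shown sits).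

The step considered is from compound 2 to compound 4 `CC(=O)O/N=C(\C)c1ccc(Sc2cc(F)cc(C3CCOCC3)c2)cc1`. The change: a group of 7 heavy atoms (4 carbon, 1 nitrogen, 2 oxygen; no ring) in place of a group of 6 heavy atoms (3 carbon, 2 nitrogen, 1 oxygen; no ring), on an aromatic carbon

Among the measured compounds shown here, the only measured step touching this part of the structure is a 7.0-fold higher number from compound 1 to compound 2 (0.85 log units; beyond the scatter). That step runs in the opposite sense: it goes from a substituted oxime oxygen to the group that compound 4 now gives up. For the measured compounds named here, compound 4 returns to a substituted oxime oxygen carrying a methyl group on the carbon, as compound 1 does, so the reverse of that step is the expectation, though the entering group is not the one found in compound 1, and some of the gain may not be recovered.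

For compound 4 the expected step is a 4.0-fold lower number from compound 2 to compound 4 (0.60 log units; beyond the scatter). The estimate for compound 4 in this assay is 70 nM, with a range from 25 nM to 200 nM.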

Compound 4, half-maximal inhibitory concentration: 50 nM
The estimate for compound 4 lay 1.4-fold (0.15 log units) above the measured number, and the stated range covers the measured number.
By their numbers in this assay, from the lowest: compounds 1 and 4 (each within the scatter of the next); then compound 2. At a limit, above all of these: compound 3.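

At the aromatic carbon para to a large group, the group entering in compound 4 gives a 5.6-fold lower number from compound 2 to compound 4 (0.75 log units; beyond the scatter) in this assay, so the lower number seen with 2-fluoroethyl on the oxime oxygen of compound 1 is not confined to that one substituent. With acetyl in place of 2-fluoroethyl on that oxygen, the result is a 1.3-fold higher number from compound 1 to compound 4 (0.10 log units; within the scatter) and the two substituents cannot be told apart in this read-out, even though acetyl brings a carbonyl and 2-fluoroethyl a fluorine. The group leaving compound 2 has 1 hydrogen-bond donor and the group entering in compound 4 has 0 hydrogen-bond donors, but that step also alters the substituent on the oxime carbon, so it cannot be assigned to either difference alone.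

Nothing measured in this set gives a reason for either step. As far as these compounds go, it remains open whether a longer chain on the oxime oxygen, such as 3-fluoropropyl, or a chain ending in an amine or a carboxylic acid, would keep the number in the range of compound 1 and compound 4.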